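The compounds below may be only part of what the source reports. "The series", "measured", "known", "first", "only" and "open" are said of these compounds alone.

Measured so far: compound 1 `COc1ccc(/C=C/C2CC(=O)C=CO2)cc1OC` with 146 uM, compound 2 `COc1cc(/C=C/C2CC(=O)C=CO2)cc(OC)c1OC` with 223 uM, and compound 3 `COc1ccc(/C=C/C2CC=CC(=O)O2)cc1OC` with 11.6 uM, all in a functional assay on NCI/ADR cells (Homo sapiens) for inhibition, read by sulforhodamine B assay, with a stated time of 48 h; on this read-out higher numbers stand for weaker inhibition of growth and lower numbers for stronger inhibition of growth.

Compound 2 differs from compound 1 by methoxy in place of hydrogen on an aromatic carbon, and that change gave a 1.5-fold higher number from compound 1 to compound 2 (0.18 log units; within the scatter). Compound 3 has a different core from compound 1; the difference between the two cores is not broken down here. Compound 4 `COc1cc(OC)c(OC)cc1/C=C/C1CC=CC(=O)O1` has not yet been measured; it differs from compound 3 by methoxy in place of hydrogen on an aromatic carbon. This is the same kind of change as from compound 1 to compound 2, but the surroundings differ: in compound 4 the entering methoxy sits ortho to a group of 9 heavy atoms, meta to a methoxy group and para to a methoxy group, whereas in compound 2 it sits ortho to a methoxy group, meta to a group of 9 heavy atoms and meta to a methoxy group. Because the earlier step of a 1.5-fold higher number from compound 1 to compound 2 (0.18 log units; within the scatter) stayed within the scatter, a small step of a 1.3-fold higher number from compound 3 to compound 4 (0.11 log units; within the scatter) is expected from compound 3 to compound 4 in this assay. Compound 4 is therefore estimated at 15 uM, most likely between 6 uM and 40 uM.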

Compound 4, concentration for growth inhibition (reported as GI): 9.4 uM
The estimate for compound 4 lay 1.6-fold (0.20 log units) above the measured number, within the range that was stated.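

On the second core, methoxy in place of hydrogen gave a 1.2-fold lower number from compound 3 to compound 4 (0.09 log units; within the scatter) in this assay, so the step stays within the scatter here too. Set side by side, the two steps do not differ: the same change on two cores in this assay, a 1.5-fold higher number (0.18 log units; within the scatter) from compound 1 to compound 2 and a 1.2-fold lower number (0.09 log units; within the scatter) from compound 3 to compound 4, 1.9-fold (0.28 log units) apart, within the scatter of two such steps

This shows that the change stayed small in these two pairs, but not that it would stay small on any other core, and the methoxy also enters at a different place in each pair.

The aromatic ring carries only methoxy groups in the compounds shown, so a hydroxyl, an amine or a carboxylic acid there remains open. Also open, going by these compounds, is which part of the core sets compound 1 at 146 uM apart from compound 3 at 11.6 uM.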